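Isopropyl on the aryl ether: a cytotoxicity comparison

The compounds below may be only part of what the source reports. "The series", "measured", "known", "first", "only" and "open" are said of these compounds alone.

Compound 1, `O=C(NCCNS(=O)(=O)c1sccc1-c1ccccc1Oc1ccc(O)c(O)c1)Nc1cc(Cl)cc(Cl)c1`, gives 10700 nM in an ADME assay on HEK-293T cells (Homo sapiens) for cytotoxicity, read by CCK-8 assay, with a stated time of 48 h; on this read-out lower numbers stand for stronger inhibition and higher numbers for weaker inhibition.
Compound 2, `CC(C)c1ccc(Oc2ccc(O)c(O)c2)c(-c2ccsc2S(=O)(=O)NCCNC(=O)Nc2cc(Cl)cc(Cl)c2)c1`, gives in this assay only a limit, > 10000 nM.
Compound 3, `O=C(NCCNS(=O)(=O)c1sccc1-c1ccccc1Oc1ccc(O)c(O)c1)Nc1cc(C(F)(F)F)cc(C(F)(F)F)c1`, gives 8900 nM in this assay.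

Compound 4, `CC(C)c1ccc(Oc2ccc(O)c(O)c2)c(-c2ccsc2S(=O)(=O)NCCNC(=O)Nc2cc(C(F)(F)F)cc(C(F)(F)F)c2)c1`, has not been measured in this assay.

Compound 4 is related to compound 3 by isopropyl in place of hydrogen on an aromatic carbon. The same change, (isopropyl in place of hydrogen on an aromatic carbon), connects the two measured compounds 1 and 2; the place lines of the two changes read the same, so this is the same change made on a second core. How the core of compound 3 differs from the core of compound 1 is not broken down here. The step that the limit leaves unreadable from compound 1 to compound 2 cannot be sized, because the limit of > 10000 nM in this assay, at which 1 of the 3 values shown sits, means that compound 2 returned no number. Compound 3 and compound 1 stand within the usual scatter of each other, so no order between them is read.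

With the measured instance of this change giving only a limit, the step expected from compound 3 to compound 4 in this assay is weak at best, and the estimated step is a 1.3-fold higher number from compound 3 to compound 4 (0.13 log units; within the scatter). On that basis compound 4 is expected to give about 12000 nM, with a likely range from 6000 nM to 25000 nM, and a real chance that this assay reports only a limit for compound 4.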

Compound 4, half-maximal inhibitory concentration: > 20000 nM
Compound 4 was reported as a limit (the forecaster's own chance of this, stated with the estimate: 55%); middle value at least 1.6-fold (0.22 log units) from the limit.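

In this assay, the change of hydrogen to isopropyl on the aromatic carbon para to the 3,4-dihydroxyphenoxy group gives an at least 2.2-fold higher number from compound 3 to compound 4 (0.35 log units; beyond the scatter), which makes the core of compound 3 the only place in this series where the change can be read as a step. On the core of compound 1 the same change cannot be read, so the measured pair there neither supports nor goes against this result, as compound 2 is reported only as a limit: the limit of > 10000 nM in this assay, at which 1 of the 4 values shown sits. The result therefore does not show that the change acts alike on the two cores, nor does it give the full size of the step on the core of compound 3, since compound 4 is also reported only as a limit: the limit of > 20000 nM in this assay, at which 1 of the 4 values shown sits.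

The compounds shown leave open whether a methyl, a tert-butyl, an amine or a carboxylic acid on that same aromatic carbon would shift the number as isopropyl does. They also leave open how the change would read on a third core, for instance one carrying nitrile groups in place of the two trifluoromethyl groups of compound 3.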